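A few compounds are considered here, and "the series" means these few. Any claim that something is new, unique, unknown or untested is made for them only; others in the source may bear on it.

Compound 1 `O=C(CCCCCC(=O)Nc1ccc(O)c(C(=O)Nc2ccccc2)c1)NO`: 5850 nM
Compound 2 `O=C(CCCCCC(=O)Nc1ccc(O)c(C(=O)Nc2ccc(F)c(F)c2)c1)NO`: 4010 nM

In a functional assay on A-431 cells (Homo sapiens) for antiproliferative activity, read by MTT assay, with a stated time of 48 h (on this read-out lower numbers stand for stronger inhibition and higher numbers for weaker inhibition), compound 1 gives 5850 nM. Of the two measured compounds it carries the higher number, but compound 2, at 4010 nM, lies within the scatter of it, so the two cannot be ranked. Compound 3 `C#Cc1cccc(NC(=O)c2cc(NC(=O)CCCCCC(=O)NO)ccc2O)c1` has not yet been measured. It differs from compound 1 as follows: ethynyl in place of hydrogen on an aromatic carbon. In other words, phenyl becomes 3-ethynylphenyl. Among the measured compounds shown here, only one measured step bears on this, a 1.5-fold lower number from compound 1 to compound 2 (0.16 log units; within the scatter), which replaces the same phenyl with 3,4-difluorophenyl and stays within the scatter. It involves a different group, so it is weak guidance, but it gives no reason to expect a step beyond the scatter in this assay. The expected change is a 1.3-fold lower number from compound 1 to compound 3 (0.11 log units; within the scatter). Compound 3 is estimated at 4500 nM, with an expected range of 1800 nM to 10000 nM.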

Compound 3, half-maximal inhibitory concentration: 5750 nM
Compound 3: middle estimate off by 1.3-fold (0.11 log units), on the low side, within the range that was stated.
By their numbers in this assay, from the lowest: compounds 2, 3 and 1 (each within the scatter of the next).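

Among the compounds shown here, with ethynyl in place of hydrogen on an aromatic carbon, meta to a large group, this assay shows a 1.0-fold lower number from compound 1 to compound 3 (0.01 log units; within the scatter), so this change to the phenyl on the amide-type nitrogen gives no step that can be told from the scatter. The comparison with the other substituted ring, a 1.4-fold higher number from compound 2 to compound 3 (0.16 log units; within the scatter), also stays within the scatter, so 3-ethynylphenyl and 3,4-difluorophenyl cannot be ranked against each other in this assay. No separate measurement is available that could account for these results.

From the compounds shown here alone, whether an amine or a carboxylic acid at this ring position would give a step beyond the scatter remains open. The compounds shown also leave open how a longer chain such as propynyl would compare with ethynyl.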